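The source may hold more compounds than are shown below. What is called first, only, known or untested is meant among the compounds shown, and "the series" means these compounds.

Compound 1 `CC(C)n1ncc2c(C(=O)NCc3cn(-c4ccccc4)nn3)cccc21`: in a functional assay on HepG2 cells (Homo sapiens) for inhibition, read by MTT assay, with a stated time of 72 h (on this read-out lower numbers stand for stronger inhibition and higher numbers for weaker inhibition), compound 1 gives > 40000 nM, which is a limit of the assay rather than a number.
Compound 2 `Cc1ccc(-n2cc(CNC(=O)c3cccc4c3cnn4C(C)C)nn2)c(C)c1`: in this assay compound 2 gives > 40000 nM, which is likewise a limit of the assay.

Compound 2 therefore stands at the top of what this assay reports, at the limit of > 40000 nM in this assay, at which 2 of the 2 values shown sit. Among the compounds with values here, both measured compounds sit there, so the one step between them, a step that the two limits leave unreadable from compound 1 to compound 2, cannot be read in size or direction.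

Compound 3 `CC(C)n1ncc2c(C(=O)NCc3cn(-c4ccc(I)cc4)nn3)cccc21` differs from compound 2 in one place: 4-iodophenyl in place of 2,4-dimethylphenyl on an aromatic nitrogen. Within the data shown here, no measured step bears on this exchange, and the one step that is known gives no readable size. Nothing in the two values points to a change beyond the scatter, so the expectation rests on compound 2 standing at > 40000 nM, a limit.

Compound 3 is thus expected to give 40000 nM in this assay, estimated to lie between 10000 nM and 150000 nM. The expected step is a number no higher from compound 2 to compound 3 (the limit leaves the size open), which amounts to no change beyond the scatter; most likely this assay will again report only a limit for compound 3.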

Compound 3, half-maximal inhibitory concentration: > 40000 nM
Compound 3 gave a limit, no number (the forecaster's own chance of this, stated with the estimate: 80%); the middle value lies on the limit itself.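

Compound 1, compound 2 and compound 3 each give only a limit, not a number, in this assay, so no step among them can be read in size or direction: the limit of > 40000 nM in this assay, at which 3 of the 3 values shown sit.

Going by these compounds, whether phenyl, 2,4-dimethylphenyl and 4-iodophenyl differ at all in their effect stays open, as does which change to the shared core would yield a measurable value.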